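The compounds below may be only part of what the source reports. "The series", "measured", "known", "first", "only" and "open" are said of these compounds alone.

Compound 1 `COc1cc(OC)c(-c2coc3cc(OCC=C(C)C)ccc3c2=O)cc1OC`: 3500 nM
Compound 2 `COc1cc(OC)c(-c2coc3cc(OCc4ccccc4C(F)(F)F)ccc3c2=O)cc1OC`: > 10000 nM

Both compounds were tested in a functional assay on U-251 cells (Homo sapiens) for antiproliferative activity, read by MTT assay, with a stated time of 24 h; a lower number here means a stronger inhibitor, a higher number a weaker inhibitor. Compound 2 gives only a limit of the assay, > 10000 nM, and not a number.

Compound 3 `COc1cc(OC)c(-c2coc3cc(OCc4ccc(C#N)cc4)ccc3c2=O)cc1OC` differs from compound 2 in one place: 4-cyanophenyl in place of 2-(trifluoromethyl)phenyl on a saturated chain carbon bound to an oxygen on an aromatic ring. It carries 4-cyanophenyl in place of 2-(trifluoromethyl)phenyl on a saturated chain carbon bound to an oxygen on an aromatic ring.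

Within the data shown here, only one measured step bears on this change: an at least 2.8-fold higher number from compound 1 to compound 2 (0.45 log units; beyond the scatter). On these data alone, that step brought in 2-(trifluoromethyl)phenyl at the same place and ended at the limit, so its full size is unknown. Among the measured compounds shown here, no measured compound carries 4-cyanophenyl. A modest move towards a lower number is therefore expected, though it may not exceed the scatter.

The expected result is an at least 1.4-fold lower number from compound 2 to compound 3 (0.15 log units; that floor lies within the scatter). For compound 3 the estimated value is 7000 nM, with an expected range from 2500 nM to 20000 nM.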

Compound 3, half-maximal inhibitory concentration: 6180 nM
The estimate for compound 3 lay 1.1-fold (0.05 log units) above the measured number; the range from low to high includes it.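

Compound 3 gives a measured value in this assay, which shows that a benzyl group at this place, on a saturated chain carbon bound to an oxygen on an aromatic ring, need not end at the limit of the assay. Exchanging 2-(trifluoromethyl)benzyl for 4-cyanobenzyl gives an at least 1.6-fold lower number from compound 2 to compound 3 (0.20 log units; that floor lies within the scatter), and only this floor can be stated because compound 2 stands at the limit, which is not a number: the limit of > 10000 nM in this assay, at which 1 of the 3 values shown sits. Set against the open-chain group of compound 1, 4-cyanophenyl gives a 1.8-fold higher number from compound 1 to compound 3 (0.25 log units; within the scatter), so these two groups cannot be told apart here.

The compounds shown do not separate the effect of the nitrile from that of the trifluoromethyl or of their places on the ring. Also open, on these data alone, is how an unsubstituted benzyl, a carboxylic acid or a longer chain would read at this place.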